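Amine replacement on the chain of a biaryl urea series

The source may report more compounds than this note shows. Statements on the series, on what has been measured and on what is new or still open speak of the compounds shown alone.

Compound 1 `CN(C)CCN(C(=O)Nc1cc(Cl)cc(Cl)c1)c1ccc(-c2cccc(C#N)c2)cc1`: 19 nM
Compound 2 `CN(C)CCN(C(=O)Nc1ccc(C(F)(F)F)c(F)c1)c1ccc(-c2cccc(C#N)c2)cc1`: 6 nM

In an assay on isolated protein for inhibition of melanin-concentrating hormone receptor 1 (Homo sapiens) (on this read-out higher numbers stand for weaker inhibition and lower numbers for stronger inhibition), compound 1 gives 19 nM, the highest of the two numbers; compound 2 sits at 6 nM, and the step of a 3.2-fold lower number from compound 1 to compound 2 (0.50 log units; beyond the scatter) concerns the aryl group on the urea nitrogen only. Compound 3 `N#Cc1cccc(-c2ccc(N(CCN3CC[C@@H](O)C3)C(=O)Nc3cc(Cl)cc(Cl)c3)cc2)c1` differs from compound 1 by 3-hydroxypyrrolidin-1-yl in place of dimethylamino on a saturated chain carbon, two bonds along the chain from an amide-type nitrogen. Among the compounds with values here, no measured step touches the chain amine, so the expectation for compound 3 rests on the unchanged core alone: a step of about a 1.3-fold higher number from compound 1 to compound 3 (0.12 log units; within the scatter) is expected, within the scatter. For compound 3 the estimate in this assay is 25 nM, with a range from 8 nM to 80 nM.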

Compound 3, inhibition constant: 11 nM
Beside the measured number, compound 3's estimate is 2.3-fold (0.36 log units) above it, and the stated range covers the measured number.
By their numbers in this assay, from the lowest: compounds 2, 3 and 1 (each within the scatter of the next, the first and the last beyond it).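

In this assay, the chain position takes 3-hydroxypyrrolidin-1-yl in place of dimethylamino with a 1.7-fold lower number from compound 1 to compound 3 (0.24 log units; within the scatter), so a five-membered non-aromatic ring carrying a hydrogen-bond donor and a defined stereocentre is tolerated here without a step beyond the scatter. Within the data shown here, this is the first reading on the chain amine, as the earlier pair varied only the aryl group on the urea nitrogen. No data here offer an explanation for this result.

Still open, on these data alone, is whether the hydroxyl matters, which plain pyrrolidin-1-yl or morpholin-4-yl on the chain would test. Also open, as far as these compounds go, is how 3-hydroxypyrrolidin-1-yl reads alongside the 3-fluoro-4-(trifluoromethyl)phenyl group of compound 2.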